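Swapping the benzylidene ring: from chlorohydroxyphenyl to fluorophenyl

The compounds below may be only part of what the source reports. "The series", "measured", "known", "first", "only" and "open" are said of these compounds alone.

Compounds measured so far:
compound 1 `Cc1c(C(=O)N/N=C\c2cc(O)ccc2O)oc2cccc(O)c12` gives 95500 nM
compound 2 `Cc1c(C(=O)N/N=C\c2ccccc2)oc2cccc(O)c12` gives 29200 nM
compound 3 `Cc1c(C(=O)N/N=C\c2cc(Cl)ccc2O)oc2cccc(O)c12` gives 3120 nM

In a functional assay on PC-3 cells (Homo sapiens) for inhibition (on this read-out lower numbers stand for stronger inhibition and higher numbers for weaker inhibition), compound 3 stands lowest of the three, with the steps to compound 2 and to compound 1 both beyond the scatter. Compound 4 `Cc1c(C(=O)N/N=C\c2ccc(F)cc2)oc2cccc(O)c12` has not yet been measured; it differs from compound 3 by 4-fluorophenyl in place of 5-chloro-2-hydroxyphenyl on a carbon with a double bond to nitrogen. For the measured compounds named here, two measured steps bear on this change. The step of a 9.4-fold lower number from compound 2 to compound 3 (0.97 log units; beyond the scatter) shows what the 5-chloro-2-hydroxyphenyl ring adds over bare phenyl, and the step of a 31-fold lower number from compound 1 to compound 3 (1.49 log units; beyond the scatter) shows how much the pattern on that ring matters. Since compound 4 carries only a fluorine on an otherwise plain phenyl ring, it is expected to sit closer to compound 2 than to compound 3, an expected step of a 6.4-fold higher number from compound 3 to compound 4 (0.81 log units; beyond the scatter). Compound 4 is therefore estimated at 20000 nM, with a range from 5000 nM to 70000 nM.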

Compound 4, half-maximal inhibitory concentration: >= 40000 nM
Compound 4 was reported as a limit; the forecaster's own chance of this, stated with the estimate: 10%; at least 2.0-fold (0.30 log units) between middle value and limit.
By their numbers in this assay, from the lowest: compound 3; then compound 2; then compound 1.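

Compound 4 is reported in this assay only as a limit: the limit of >= 40000 nM in this assay, at which 1 of the 4 values shown sits.

Replacing the 5-chloro-2-hydroxyphenyl ring with 4-fluorophenyl gives an at least 12-fold higher number from compound 3 to compound 4 (1.10 log units; beyond the scatter), so a lone fluoro on the ring does not retain the inhibition seen with compound 3. Fluoro in place of hydrogen on bare phenyl gives an at least 1.3-fold higher number from compound 2 to compound 4 (0.13 log units; that floor lies within the scatter), which shows no gain from fluoro, and the step involving compound 1 cannot be read.

Still open, from the compounds shown here alone, is which of the chloro and the hydroxy carries the stronger inhibition of compound 3, and whether a methoxy or an amine in place of that hydroxy would keep it.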